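The compounds below may be only part of what the source reports. "The series", "measured", "known", "first", "only" and "open" are said of these compounds alone.

In a functional assay on HL-60 cells (Homo sapiens) for inhibition, read by MTT assay, with a stated time of 72 h (on this read-out lower numbers stand for stronger inhibition and higher numbers for weaker inhibition), compound 1 `CCc1nc(-c2ccc(C(C)(C)C)cc2)c(C(=O)N2CCN(c3cccc(OC)c3)CC2)o1` is reported as "not active" (no number reported), while compound 2 `CCc1nc(-c2ccc(F)cc2)c(C(=O)N2CCN(c3cccc(Cl)c3)CC2)o1` gives 169 nM. Compound 3 `CCc1nc(-c2ccc(C(C)C)cc2)c(C(=O)N2CCN(c3cccc(OC)c3)CC2)o1` gives 887 nM, the higher of the two numbers and therefore the weaker result, with a gap beyond the usual scatter. Compound 4 `CCc1nc(-c2ccc(F)cc2)c(C(=O)N2CCN(c3cccc(OC)c3)CC2)o1` has not yet been measured. The change from compound 3 is fluoro in place of isopropyl on an aromatic carbon. Within the data shown here, no measured pair shows this change alone, so the evidence is indirect. Among the measured compounds shown here, the only guide is that compound 2, which also carries the 4-fluorophenyl, gives 169 nM. A lower number is therefore expected, and the estimated step is a 3.5-fold lower number from compound 3 to compound 4 (0.55 log units; beyond the scatter), probably beyond the scatter. For compound 4 the estimated value is 250 nM, with an expected range from 70 nM to 800 nM.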

Compound 4, half-maximal inhibitory concentration: 411 nM
Compound 4: the middle estimate sits 1.6-fold (0.22 log units) below what was measured; measured number inside the range.
By their numbers in this assay, from the lowest: compound 2; then compound 4; then compound 3.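

In this assay, among these compounds, 4-fluorophenyl in place of 4-isopropylphenyl gives a 2.2-fold lower number from compound 3 to compound 4 (0.33 log units; beyond the scatter) with the methoxy group unchanged, the first direct reading of this change. With the 4-fluorophenyl unchanged, methoxy in place of chloro on an aromatic carbon gives a 2.4-fold higher number from compound 2 to compound 4 (0.39 log units; beyond the scatter) in the opposite direction, so neither place alone accounts for the gap between the earlier numbers. Nothing measured here explains why either step occurs. Still open, as far as these compounds go, is how an amine or a carboxylic acid in place of the fluoro would read in this assay, and whether the two steps would hold on other versions of the core.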